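Quinone enol demethylation in a naphthoyl amide series

The compounds below may be only part of what the source reports. "The series", "measured", "known", "first", "only" and "open" are said of these compounds alone.

Three measured compounds share the core of compound 1 `CC(C)(CNC(=O)c1ccc2ccccc2c1)CC1=C(O)C(=O)c2ccccc2C1=O`, which in a functional assay on MCF7 cells (Homo sapiens) for cytotoxicity, read by resazurin assay, with a stated time of 3 days (a lower number here means a stronger inhibitor, a higher number a weaker inhibitor), gives 28200 nM. For the measured compounds named here, compound 2 `CC(C)(CNC(=O)c1ccc2ccccc2c1O)CC1=C(O)C(=O)c2ccccc2C1=O` carries a hydroxy on the naphthoyl ring and gives 79500 nM; the one step that differs in a single place is a 2.8-fold higher number from compound 1 to compound 2 (0.45 log units; beyond the scatter). Compound 3 `COC1=C(CC(C)(C)CNC(=O)c2ccc3ccccc3c2OC)C(=O)c2ccccc2C1=O`, with both oxygens methylated, gives 95700 nM and stands highest of the three numbers, though its gap to compound 2 is within the scatter while its gap to compound 1 lies beyond it.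

Compound 4 `COc1c(C(=O)NCC(C)(C)CC2=C(O)C(=O)c3ccccc3C2=O)ccc2ccccc12` differs from compound 3 by hydrogen in place of methyl on an oxygen on an unsaturated carbon, restoring the free enol on the quinone core while the naphthoyl methoxy remains. Going by the values given here, no measured step isolates this change. Compound 2 and compound 3 differ at both oxygens, and their values sit within the scatter of each other, which gives no sign that removing the quinone methyl shifts the number. The step from compound 1 to compound 2 concerns the naphthoyl oxygen only and is modest. For compound 4 no step beyond the scatter is therefore expected, and the estimate is a 1.1-fold lower number from compound 3 to compound 4 (0.05 log units; within the scatter). Compound 4 is expected to give about 85000 nM, within 40000 nM to 180000 nM.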

Compound 4, half-maximal inhibitory concentration: 39800 nM
Compound 4: the middle estimate sits 2.1-fold (0.33 log units) above what was measured; the whole stated range lies above it.
By their numbers in this assay, from the lowest: compounds 1, 4, 2 and 3 (each within the scatter of the next, the first and the last beyond it).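

Hydrogen in place of methyl on the oxygen on an unsaturated carbon now has a read of its own in this assay: a 2.4-fold lower number from compound 3 to compound 4 (0.38 log units; beyond the scatter). For the compounds shown here, this is the first sign that this oxygen matters with the methoxy held constant, which the earlier comparison, changing two oxygens at once, could not show. With the free enol held, the aromatic position reads differently: a 2.0-fold lower number from compound 2 to compound 4 (0.30 log units; within the scatter) for methyl in place of hydrogen on the oxygen on an aromatic ring, and a 1.4-fold higher number from compound 1 to compound 4 (0.15 log units; within the scatter) for a methoxy group added at that position, whereas hydroxy at that carbon gave a 2.8-fold higher number from compound 1 to compound 2 (0.45 log units; beyond the scatter). Nothing available here gives a reason for these differences.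

From the compounds shown here alone, whether the enol step keeps its size when the aromatic carbon holds hydrogen or hydroxy rather than methoxy remains open. So does the reading for a longer chain such as ethyl on the enol oxygen, or for an amine or a carboxylic acid on the aromatic carbon.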